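This account rests on a few compounds, and the source may have more. Where it says the series, first, only, none or still open, it means among the compounds named here.

Compound 1 `ClCc1ccccc1Cn1cnc2c(Cl)nc(Cl)nc21`: 1510 nM
Compound 2 `ClCc1cccc(Cn2cnc3c(Cl)ncnc32)c1`: 1900 nM
Compound 3 `ClCc1cccc(Cn2cnc3nc(Cl)nc(Cl)c32)c1`: 1540 nM

All three were tested in a functional assay on NCI-H23 cells (Homo sapiens) for cytotoxicity, read by sulforhodamine B assay, with a stated time of 48 h; on this read-out higher numbers stand for weaker inhibition of growth and lower numbers for stronger inhibition of growth. Compound 1 gives the lowest of the three numbers, yet its gaps to compound 3 and to compound 2 both lie within the usual scatter, so no order among them can be claimed. Compound 4 `Nc1nc(Cl)c2ncn(Cc3ccccc3CCl)c2n1` has not been measured yet. It differs from compound 1 in one place: amino in place of chloro on an aromatic carbon, on an aromatic carbon of the shared core, between two ring nitrogen atoms. For the measured compounds named here, no measured pair shows the effect of this exchange, so the expectation rests on the three values alone: a small step to a higher number in this assay, or none beyond the scatter, is expected. For compound 4 the estimate is 2500 nM, with a range from 900 nM to 7000 nM. This corresponds to an expected step of a 1.7-fold higher number from compound 1 to compound 4 (0.22 log units; within the scatter).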

Compound 4, concentration for 50% growth inhibition: 3020 nM
Estimate against measurement, compound 4: 1.2-fold (0.08 log units) below; the measured number falls inside the stated range.
By their numbers in this assay, from the lowest: compounds 1, 3, 2 and 4 (each within the scatter of the next).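

In this assay, the exchange of amino in place of chloro on an aromatic carbon, between two ring nitrogen atoms, gives a 2.0-fold higher number from compound 1 to compound 4 (0.30 log units; within the scatter). For the compounds shown here, this is the first reading at this position, and it gives no sign that growth inhibition in these cells depends on the chloro group there. No measurement at hand accounts for the result. On these data alone, what remains open is how other groups at this position, such as methoxy or methylamino, would read in this assay.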